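Trimming the ether chain: from isobutoxy to ethoxy

A few compounds are considered here, and "the series" means these few. Any claim that something is new, unique, unknown or untested is made for them only; others in the source may bear on it.

Compound 1 `Cc1cc(OCC(=O)N(C)C)cc(C)c1-c1cccc(COc2ccc(OCC(=O)O)c(F)c2)c1`: "not determined" (no result reported)
Compound 2 `Cc1cc(OCCCO)cc(C)c1-c1cccc(COc2ccc(OCC(=O)O)c(F)c2)c1`: 110 nM
Compound 3 `Cc1cc(OCC(C)C)cc(C)c1-c1cccc(COc2ccc(OCC(=O)O)c(F)c2)c1`: "not determined" (no result reported)

Three compounds share one core and differ only in the chain on the aryl ether. Within the data shown here, in a functional assay on CHO cells for agonist activity at Free fatty acid receptor 1 (Homo sapiens), read by FLIPR and calcium flux (a higher number here means that more compound is needed for the effect, a lower number that less compound is needed), compound 2 gives 110 nM, the only number in the set. Compound 3 carries an isobutoxy chain and in this assay stands at "not determined" (no result reported), and compound 1 likewise stands at "not determined" (no result reported). The step to compound 4 `CCOc1cc(C)c(-c2cccc(COc3ccc(OCC(=O)O)c(F)c3)c2)c(C)c1` is methyl in place of isopropyl on a saturated chain carbon bound to an oxygen on an aromatic ring, so the isobutoxy becomes an ethoxy. Among the measured compounds shown here, with no measured step to lean on, the expected change in this assay is none beyond the usual scatter around compound 2. Compound 4 is therefore expected to give about 120 nM, in a range from 35 nM to 450 nM.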

Compound 4, half-maximal effective concentration: 65.9 nM
The estimate for compound 4 lay 1.8-fold (0.26 log units) above the measured number; low and high end bracket the measured number.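

In this assay, among these compounds, there is now a first readable step at this position, a 1.7-fold lower number from compound 2 to compound 4 (0.22 log units; within the scatter), so replacing the hydroxymethyl with hydrogen leaves the number within the scatter, and the chain's terminal hydroxyl is not needed for activity at this level. The step from isobutoxy to ethoxy itself cannot be read, as compound 3 has no reported number, and neither can any step from compound 1.

From the compounds shown here alone, how an amine or a longer chain would read at this position stays open. Nothing measured here explains why compound 2 and compound 4 read alike.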